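Chloromethylbenzyl-substituted purine analogues: cytotoxicity working notes

This account rests on a few compounds, and the source may have more. Where it says the series, first, only, none or still open, it means among the compounds named here.

Values in a functional assay on NCI-H23 cells (Homo sapiens) for cytotoxicity, read by sulforhodamine B assay, with a stated time of 48 h; a higher number here means that more compound is tolerated, a lower number that less compound is tolerated:
compound 1 `ClCc1ccc(Cn2cnc3c(Cl)ncnc32)cc1`: 7760 nM
compound 2 `Nc1nc(Cl)c2ncn(Cc3ccccc3CCl)c2n1`: 78900 nM
compound 3 `ClCc1ccccc1Cn1cnc2nc(Cl)nc(Cl)c21`: 87100 nM

Compound 3 gives the highest of the three numbers. Compound 2 lies within the scatter of it, so no order between the two can be claimed. Within the data shown here, compound 1 lies well beyond the scatter below compound 3 and is the only compound of the three with a clearly lower number.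

Compound 4 `ClCc1ccccc1Cn1cnc2ncnc(Cl)c21` has not yet been measured. It differs from compound 3 by hydrogen in place of chloro on an aromatic carbon. Among the measured compounds shown here, no measured pair isolates this change, so the expectation rests on the spread of the three values. The step from compound 3 to compound 4 is expected to be a 2.2-fold lower number from compound 3 to compound 4 (0.34 log units; beyond the scatter), a moderate fall, because compound 1 at 7760 nM shows that a lower number is reachable within this series. Compound 4 is estimated at 40000 nM, with a range of 10000 nM to 150000 nM.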

Compound 4, concentration lethal to 50% of the cells: 49000 nM
For compound 4 the middle estimate is 1.2-fold (0.09 log units) below the measured one; low and high end bracket the measured number.
By their numbers in this assay, from the lowest: compound 1; then compounds 4, 2 and 3 (each within the scatter of the next).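

In this assay, among these compounds, a 1.8-fold lower number from compound 3 to compound 4 (0.25 log units; within the scatter) is the only step that isolates one change: hydrogen in place of chloro on an aromatic carbon between two ring nitrogen atoms. As this step lies within the scatter, the pair shows no readable effect of losing this chloro group. No evidence on the cause of this result is available.

As far as these compounds go, whether an amine or a methoxy group on this carbon would give a number beyond the scatter of compound 3 stays open. From the compounds shown here alone, the change is also seen in this single pair only, so its behaviour with other substituents on the shared core is unknown.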